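The source may hold more compounds than are shown below. What is called first, only, known or untested is meant among the compounds shown, and "the series" means these compounds.

The measured compounds, with their half-maximal inhibitory concentrations in a functional assay on MCF7 cells (Homo sapiens) for cytotoxicity, read by MTT assay, with a stated time of 72 h; a lower number here means a stronger inhibitor, a higher number a weaker inhibitor:

Compound 1, `O=[N+]([O-])c1ccc(-c2nnc3nnc(N4CCCCC4)n3n2)cc1`, gives only a limit of the assay, > 100000 nM.
Compound 2, `CC(C)(C)c1nnc2nnc(N3CCCC3)nn12`, gives 55000 nM.
Compound 3, `Clc1ccc(-c2nnc3nnc(N4CCCC4)nn23)c(Cl)c1`, gives 19600 nM.

Of the two compounds with a number, compound 2 stands highest; the nearest is compound 3, whose number is lower by a margin beyond the usual scatter. Compound 1 sits at the limit of > 100000 nM in this assay, at which 1 of the 3 values shown sits, and gives no number at all.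

The piece follows compound 2 to compound 4, `C1CCC(c2nnc3nnc(N4CCCC4)nn23)CC1`, which is not yet measured. The change is cyclohexyl in place of tert-butyl on an aromatic carbon. Within the data shown here, no measured pair in this set differs in one place, so there is no step of this kind to lean on; the only comparison is between an alkyl group and an aryl group on the shared core, which is a different kind of change. For compound 4 the step of a 1.6-fold lower number from compound 2 to compound 4 (0.20 log units; within the scatter) is expected to be small, at most a modest move toward a lower number, and quite possibly within the scatter. Compound 4 is accordingly estimated at 35000 nM in this assay, with a range from 10000 nM to 120000 nM.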

Compound 4, half-maximal inhibitory concentration: 37700 nM
For compound 4 the middle estimate is 1.1-fold (0.03 log units) below the measured one; measured number inside the range.
By their numbers in this assay, from the lowest: compounds 3, 4 and 2 (each within the scatter of the next, the first and the last beyond it). At a limit, above all of these: compound 1.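

Cyclohexyl in place of tert-butyl on an aromatic carbon of the five-membered aromatic ring with 3 nitrogen gives, in this assay, a 1.5-fold lower number from compound 2 to compound 4 (0.16 log units; within the scatter), and this is the first pair in the set that differs in one place. Among these compounds, with the rest of the shared core held fixed, it shows that at this position, between two ring nitrogen atoms, one six-membered non-aromatic ring of carbon only can stand where tert-butyl stood without a change that can be read, something the earlier compounds, which differ in more than one place, could not show. Nothing measured here bears on why the two groups read alike.

Going by these compounds, both groups at this position hold carbon only, so it remains open whether an amine or a carboxylic acid on the cyclohexyl ring, or a morpholine in its place, would move the number beyond the scatter. On these data alone, it also remains open whether a small group such as methyl at this position would read any differently from tert-butyl and cyclohexyl.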